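Bromo Added to a Compound at the Assay Limit

The source may hold more compounds than are shown below. What is called first, only, known or untested is meant among the compounds shown, and "the series" means these compounds.

Compound 1, `C(=C/c1nc2ncccc2[nH]1)\c1ccccc1`, gives 4390 nM in a functional assay on MIA PaCa-2 cells (Homo sapiens) for antiproliferative activity, read by MTT assay, with a stated time of 72 h; on this read-out higher numbers stand for weaker inhibition and lower numbers for stronger inhibition.
Compound 2, `N#Cc1ccc(/C=C/c2nc3ncccc3[nH]2)cc1`, gives only > 100000 nM in this assay, which is a limit of the assay and not a number.

Among the measured compounds shown here, compound 2 stands at the limit of > 100000 nM in this assay, at which 1 of the 2 values shown sits; of the two measured compounds it is the one whose number the assay could not resolve. For the measured compounds named here, the single measured step, an at least 22-fold higher number from compound 1 to compound 2 (1.35 log units; beyond the scatter), concerns the nitrile and is a large loss of inhibition, not the change now at hand. The next compound, compound 3, is `N#Cc1ccc(/C=C/c2nc3ncc(Br)cc3[nH]2)cc1`. It differs from compound 2 by bromo in place of hydrogen on an aromatic carbon. Going by the values given here, no measured step involves a bromo group, and nothing among the measured compounds shows how this addition behaves in this assay. Compound 3 keeps the nitrile that accompanies the limit value of compound 2, and the expectation is therefore anchored to that limit: the expected step of a number no higher from compound 2 to compound 3 (the limit leaves the size open) is none beyond the scatter, with a high chance that compound 3 again returns only a limit. Compound 3 is estimated at 100000 nM, within a range from 30000 nM to 300000 nM.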

Compound 3, half-maximal inhibitory concentration: 8170 nM
The estimate for compound 3 lay 12-fold (1.09 log units) above the measured number; the whole stated range lies above it.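

In this assay, adding one bromine atom to the shared core brings a large gain in inhibition: an at least 12-fold lower number from compound 2 to compound 3 (1.08 log units; beyond the scatter). Compound 2 gives only a limit of the assay and not a number, so the true size of this gain stays unknown: the limit of > 100000 nM in this assay, at which 1 of the 3 values shown sits.

This position, on an aromatic carbon of the six-membered aromatic ring with 1 nitrogen and two atoms from the ring nitrogen, is therefore one where a change can restore a measurable number even with the nitrile present, as compound 3 gives 8170 nM.

What stays open is whether bromo would act the same way on compound 1, which has no nitrile, as no pair shown here tests the bromo change in that setting. The compounds shown also do not tell whether a chloro group, a methyl group or an amine at this same position would give a similar number, or what about bromo produces the gain.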